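Aryl swap on the amine nitrogen: stability notes for compound 3

This account rests on a few compounds, and the source may have more. Where it says the series, first, only, none or still open, it means among the compounds named here.

Compound 2 `COC(=O)C1=C(Nc2ccccc2F)O/C(=C\c2c[nH]c3ncccc23)C1=O` gives 30% in an ADME assay on microsomes from liver (Homo sapiens) for metabolic stability, read by LC-MS, using NADPH, with a stated time of 30 min, tested at 1 uM; on this read-out lower numbers stand for a less stable compound and higher numbers for a more stable compound. Compound 1 `COC(=O)C1=C(Nc2ccc(OC)cc2)O/C(=C\c2c[nH]c3ncccc23)C1=O` gives 33% in this assay, and the step of a number 3 percentage points lower from compound 1 to compound 2 (within the scatter) lies within the scatter, so the two numbers are not distinguished. Compound 3 `COC(=O)C1=C(Nc2ccc(C)cc2C)O/C(=C\c2c[nH]c3ncccc23)C1=O` differs from compound 2 by 2,4-dimethylphenyl in place of 2-fluorophenyl on an amine nitrogen. Going by the values given here, the only measured step, an exchange of the aryl group on the same amine nitrogen, stayed within the scatter, and no step involving a methyl-bearing phenyl has been measured. The expected step of a number 3 percentage points lower from compound 2 to compound 3 (within the scatter) is therefore small, with no direction claimed beyond the scatter. Compound 3 is estimated at 27%, with a range of 10% to 44%.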

Compound 3, percent of the compound remaining: 63%
Compound 3: middle estimate off by 36 percentage points, on the low side; measured number above the stated range.
By their numbers in this assay, from the lowest: compounds 2 and 1 (each within the scatter of the next); then compound 3.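

In this assay the aryl group on this amine nitrogen does matter: a number 33 percentage points higher from compound 2 to compound 3 (beyond the scatter) and a number 30 percentage points higher from compound 1 to compound 3 (beyond the scatter) both come with 2,4-dimethylphenyl, whereas the exchange between the two earlier aryl groups gave no step beyond the scatter. The two steps share the entering group but start from different leaving groups, so the higher number does not depend on one particular partner. Nothing available here accounts for this difference. Open, as far as these compounds go, is whether a single methyl group on the phenyl ring would be enough, and how a phenyl ring carrying a carboxylic acid or an amine would read on this nitrogen.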